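A few compounds are considered here, and "the series" means these few. Any claim that something is new, unique, unknown or untested is made for them only; others in the source may bear on it.

Measured so far:
Compound 1, `O=C(CCCCCc1ccccc1)c1nc2ncccc2[nH]1` — in an assay on HEK-293T cells for inhibition of diacylglycerol lipase-alpha (Homo sapiens), read by colorimetric assay (a lower number here means a stronger inhibitor, a higher number a weaker inhibitor), compound 1 gives 1230 nM.
Compound 2, `CS(=O)(=O)c1cnc(C(=O)CCCCCCc2ccccc2)o1` — compound 2 gives > 10000 nM, a limit of the assay rather than a number.

Compound 2 thus stands at the limit of > 10000 nM in this assay, at which 1 of the 2 values shown sits, without a measured value of its own. Compound 3, `Cc1ccc(-c2cnc(C(=O)CCCCCCc3ccccc3)o2)nc1`, differs from compound 2 in one place: 5-methylpyridin-2-yl in place of methylsulfonyl on an aromatic carbon. Among the measured compounds shown here, no measured pair shows how such a change plays out here, so the expectation rests on the two values alone. A step from compound 2 to compound 3 of an at least 3.3-fold lower number from compound 2 to compound 3 (0.52 log units; beyond the scatter) toward stronger inhibition is expected. Compound 3 is estimated at 3000 nM, within 600 nM to 12000 nM.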

Compound 3, half-maximal inhibitory concentration: > 10000 nM
Compound 3 gave a limit, no number (the forecaster's own chance of this, stated with the estimate: 35%); at least 3.3-fold (0.52 log units) between middle value and limit.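

Compound 2 and compound 3 both give a limit rather than a number, so no step between them can be read: the limit of > 10000 nM in this assay, at which 2 of the 3 values shown sit.

The compounds shown leave open whether 5-methylpyridin-2-yl in place of methylsulfonyl changes inhibition at all.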